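Changing the Aryl Group on the Shared Core

The source may hold more compounds than are shown below. What is called first, only, known or untested is meant among the compounds shown, and "the series" means these compounds.

Compound 1, `Nc1scc(CN2CCN(c3ccc(F)cc3Cl)CC2)c1C(=O)c1ccc(Cl)cc1`: -39%
Compound 2, `Nc1scc(CN2CCN(c3c(F)cccc3F)CC2)c1C(=O)c1ccc(Cl)cc1`: -65%

Both were measured in a functional assay on CHO cells with adenosine receptor A1 (Homo sapiens) as the target, read by cAMP accumulation and immunoassay, with a stated time of 6 min, tested at 1 uM; on this read-out higher numbers stand for a weaker effect at the one concentration tested and lower numbers for a stronger effect. For the measured compounds named here, compound 2 stands lowest of the two numbers; the single measured step, a number 26 percentage points lower from compound 1 to compound 2 (beyond the scatter), was modest yet beyond the scatter. Compound 3, `Nc1scc(CN2CCN(c3cccc(Cl)c3)CC2)c1C(=O)c1ccc(Cl)cc1`, has not been measured. It differs from compound 2 by 3-chlorophenyl in place of 2,6-difluorophenyl on an amine nitrogen in a ring. Going by the values given here, the only step that bears on this also swapped the aryl group on the same ring nitrogen, so a step of similar, modest size is expected, with uncertain direction. Compound 3 is therefore estimated at -45%, between -75% and -15%, an expected step of a number 20 percentage points higher from compound 2 to compound 3 (beyond the scatter).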

Compound 3, a percentage reported as activity, at one concentration (the size of the read-out at that concentration, not a potency): -59%
Beside the measured number, compound 3's estimate is 14 percentage points above it, and the stated range covers the measured number.
By their numbers in this assay, from the lowest: compounds 2 and 3 (each within the scatter of the next); then compound 1.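

Replacing 2,6-difluorophenyl with 3-chlorophenyl on the amine nitrogen in the ring gives a number 6 percentage points higher from compound 2 to compound 3 (within the scatter), so these two aryl groups cannot be told apart in this assay. Replacing 2-chloro-4-fluorophenyl with 3-chlorophenyl gives a number 20 percentage points lower from compound 1 to compound 3 (beyond the scatter), which leaves compound 1 apart from the other two. Nothing measured here explains this grouping.

Still open, on these data alone, is how a phenyl ring carrying a methoxy group or a nitrile would read at this nitrogen. The same question holds for a non-aromatic group such as cyclohexyl.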